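The source may report more compounds than this note shows. Statements on the series, on what has been measured and on what is new or still open speak of the compounds shown alone.

Compound 1: `O=C(c1ccccc1)N1CCC(NCC[S+]([O-])C(c2ccc(F)cc2)c2ccc(F)cc2)CC1` — 79.1 nM
Compound 2: `O=C(c1ccc(F)cc1)N1CCC(NCC[S+]([O-])C(c2ccc(F)cc2)c2ccc(F)cc2)CC1` — 77.2 nM
Compound 3: `O=C(c1ccccc1F)N1CCC(NCCSC(c2ccc(F)cc2)c2ccc(F)cc2)CC1` — 46.1 nM

The three compounds were tested in an assay on membranes from striatum (strain Sprague-Dawley) for displacement of a labelled ligand from sodium-dependent dopamine transporter (Rattus norvegicus), read by scintillation counting, with a stated time of 120 min; a higher number here means a weaker inhibitor, a lower number a stronger inhibitor. Compound 1 gives 79.1 nM, compound 2 gives 77.2 nM, and compound 3 gives 46.1 nM; all three numbers sit within the scatter of one another, so no order among them can be read from this assay. Compound 1 and compound 2 differ by fluoro in place of hydrogen on an aromatic carbon, and the step was a 1.0-fold lower number from compound 1 to compound 2 (0.01 log units; within the scatter). The difference between the core of compound 1 and the core of compound 3 is not broken down here.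

Compound 4, `O=C(c1ccc(F)cc1F)N1CCC(NCCSC(c2ccc(F)cc2)c2ccc(F)cc2)CC1`, has not yet been measured. It differs from compound 3 by fluoro in place of hydrogen on an aromatic carbon. This is the same kind of change as that from compound 1 to compound 2, though the place is not identical: in compound 4 the incoming fluoro sits meta to a fluoro group as well as para to a large group, whereas in compound 2 it is only para to a large group. Because the step of a 1.0-fold lower number from compound 1 to compound 2 (0.01 log units; within the scatter) stayed within the scatter, the expected step in this assay is a 1.0-fold lower number from compound 3 to compound 4 (0.00 log units; within the scatter). Compound 4 is therefore estimated at 46 nM, with a range from 25 nM to 85 nM.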

Compound 4, inhibition constant: 30 nM
Beside the measured number, compound 4's estimate is 1.5-fold (0.19 log units) above it; low and high end bracket the measured number.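

In this assay, fluoro in place of hydrogen on an aromatic carbon, which turns the 2-fluorophenyl group into the 2,4-difluorophenyl group, gave a 1.5-fold lower number from compound 3 to compound 4 (0.19 log units; within the scatter). Among the compounds shown here, the same change thus stayed within the scatter on both cores, and the two steps cannot be told apart: the same change on two cores in this assay, a 1.0-fold lower number (0.01 log units; within the scatter) from compound 1 to compound 2 and a 1.5-fold lower number (0.19 log units; within the scatter) from compound 3 to compound 4, 1.5-fold (0.18 log units) apart, within the scatter of two such steps This shows that the change carried from one core to the other without a measurable difference in this assay, but it does not show that the change is without effect in general, since only two pairs, both with steps within the scatter, bear on it, and it says nothing about any other core.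

Still open, on these data alone, is how a chloro, methoxy or trifluoromethyl group at the same place on the benzoyl ring would read in this assay. Also open, as far as these compounds go, are what a longer chain between the sulfur and the piperidine nitrogen would do, and how the sulfur-oxygen form and the plain sulfur form compare when all else is equal.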